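Growing the sulfur-bound chain: from propyl to cyclopropylmethyl

The source may report more compounds than this note shows. Statements on the series, on what has been measured and on what is new or still open speak of the compounds shown alone.

Measured compounds:
compound 1 `C#CCSc1nc(Nc2cccc(Cl)c2)c2ccncc2n1` gives 56500 nM
compound 2 `CCSc1nc(Nc2cccc(OC)c2)c2ccncc2n1` gives 7150 nM
compound 3 `CCCSc1nc(Nc2cccc(OC)c2)c2ccncc2n1` gives 15300 nM

All three share one core and differ in the group on the sulfur and in the substituent on the aniline ring. In a functional assay on PC-3 cells (Homo sapiens) for inhibition, read by MTT assay, with a stated time of 72 h (a higher number here means a weaker inhibitor, a lower number a stronger inhibitor), compound 3 stands second highest of the three numbers: compound 2 sits closest, and compound 1, which carries a chlorine on the aniline ring and a propargyl group on the sulfur, is furthest away with the highest number.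

Compound 4 `COc1cccc(Nc2nc(SCC3CC3)nc3cnccc23)c1` keeps the methoxy-substituted aniline of compound 3 and changes only the chain on the sulfur: cyclopropyl in place of ethyl on a saturated chain carbon bound to a sulfur.

Going by the values given here, one measured step bears on this change. Lengthening the chain on the sulfur from ethyl to propyl gave a 2.1-fold higher number from compound 2 to compound 3 (0.33 log units; beyond the scatter). Among the compounds with values here, the move to cyclopropylmethyl again makes the chain larger, now with a small ring at its end, so a further modest rise in this assay is expected rather than a drop, though there is no measured example of a ring on this chain.

Compound 4 is therefore estimated to give 22000 nM, with a range from 8000 nM to 60000 nM, which is expected to be a 1.4-fold higher number from compound 3 to compound 4 (0.16 log units; within the scatter).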

Compound 4, half-maximal inhibitory concentration: 14800 nM
Compound 4: the middle estimate sits 1.5-fold (0.17 log units) above what was measured; low and high end bracket the measured number.
By their numbers in this assay, from the lowest: compound 2; then compounds 4 and 3 (each within the scatter of the next); then compound 1.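

In this assay replacing the ethyl end of the propyl chain with a cyclopropyl ring gives a 1.0-fold lower number from compound 3 to compound 4 (0.01 log units; within the scatter) and so shows that a small ring can stand at the end of this sulfur-bound chain without moving the number beyond the scatter. Measured against the shorter ethyl chain, the ring-bearing chain gives a 2.1-fold higher number from compound 2 to compound 4 (0.32 log units; beyond the scatter) and the open propyl chain gives a 2.1-fold higher number from compound 2 to compound 3 (0.33 log units; beyond the scatter) so among the three compounds with the methoxy-substituted aniline, both larger chains carry higher numbers than ethyl, while ring and open chain cannot be told apart. The data shown offer no measured explanation for why the ring and the open chain read alike.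

On these data alone, it remains open whether a longer chain such as butyl or a larger ring such as cyclohexyl at the chain end would push the number higher still, or whether an amine or a carboxylic acid at the end of the chain would bring it down. Compound 1 differs from the others in both the group on the sulfur and the substituent on the aniline ring, so it cannot show the effect of either change alone.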